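Unspecified Stereocentre: Compound 3 Set Against Compound 2

The source may report more compounds than this note shows. Statements on the series, on what has been measured and on what is new or still open speak of the compounds shown alone.

Measured compounds:
compound 1, `OC(CCn1nc2c(Br)c(Br)c(Br)c(Br)c2n1)c1ccc(F)cc1`, 116%
compound 2, `C[C@H](O)CCn1nc2c(Br)c(Br)c(Br)c(Br)c2n1`, 112%

In a functional assay on MCF7 cells (Homo sapiens) for antiproliferative activity, read by MTT assay, with a stated time of 24 h, tested at 12.5 uM (a lower number here means a stronger effect, a higher number a weaker effect of the compound at the concentration tested), compound 1 gives 116% and compound 2 gives 112%. Compound 2 holds the lower of the two numbers, but its nearest neighbour, compound 1, sits within the usual scatter of it, so the two values cannot be told apart and neither compound can be called the stronger of the pair. Both numbers lie at the weak end of the read-out, with no reduction of cell viability at the concentration tested.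

Compound 3, `CC(O)CCn1nc2c(Br)c(Br)c(Br)c(Br)c2n1`, has not yet been measured in this assay. It differs from compound 2 only in how one stereo element is drawn: the two compounds have the same atoms and bonds; at least one stereo element is drawn with a configuration in one of them and without one in the other: 1 of 1 stereo elements differ; a stereocentre at a saturated chain carbon is drawn S in compound 2 and without a configuration in compound 3. Among the measured compounds shown here, no measured pair in this set isolates such a change, so there is no step to lean on. Because the atoms and bonds are the same and compound 2 gives 112%, no step beyond the scatter is expected from compound 2 to compound 3 in this assay.

Compound 3 is therefore estimated at 112%, with a range from 100% to 124%. This estimate means an expected step of no change at the digits printed from compound 2 to compound 3 (within the scatter), which is nothing beyond the scatter.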

Compound 3, a percentage reported as activity, at one concentration (the size of the read-out at that concentration, not a potency): 99%
The estimate for compound 3 lay 13 percentage points above the measured number, and the stated range ends above it.
By their numbers in this assay, from the lowest: compound 3; then compounds 2 and 1 (each within the scatter of the next).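

In this assay, among the compounds shown here, drawing the stereocentre at the saturated chain carbon without a configuration, rather than as S, comes with a number 13 percentage points lower from compound 2 to compound 3 (beyond the scatter), so this position responds to a change that leaves the atoms and bonds untouched, something no earlier pair could show. Methyl in place of 4-fluorophenyl on the same saturated chain carbon comes with a number 17 percentage points lower from compound 1 to compound 3 (beyond the scatter), the first step beyond the scatter for that exchange of groups, though it can be read only for compound 3 as drawn, without a configuration. Nothing in the structures sets compound 2 apart from compound 3 except one point: the fact that one of compounds 2 and 3 is drawn with a defined configuration and the other without, at the place where they differ

The compounds shown do not tell which configuration, or which mixture of configurations, compound 3 holds, and the R form is not among them, so it remains open whether the step belongs to one particular configuration. They also leave open how this position would read with an amine or a carboxylic acid in place of the hydroxy group, or with a longer chain in place of the methyl group.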